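Oxadiazine-core series: chloro for trifluoromethyl at the aryl ring

The compounds below may be only part of what the source reports. "The series", "measured", "known", "first", "only" and "open" are said of these compounds alone.

Measured compounds, whole-animal read-out:
compound 1 `CC1(C)OC(C)(C)c2c1nnc(-c1ccccc1)[n+]2[O-]` – 163 mg/kg
compound 2 `CC1(C)OC(C)(C)c2c1nnc(-c1cccc([N+](=O)[O-])c1)[n+]2[O-]` – 72 mg/kg
compound 3 `CC1(C)OC(C)(C)c2c1nnc(-c1cccc(C(F)(F)F)c1)[n+]2[O-]` – 66.7 mg/kg

The read-out is a functional assay on the whole organism with Mus musculus as the target; on this read-out lower numbers stand for an effect already at smaller amounts and higher numbers for an effect only at larger amounts of compound. Compound 3 gives the smallest number of the three, but the step to its nearest neighbour is only a 1.1-fold lower number from compound 2 to compound 3 (0.03 log units; within the scatter), so the two cannot be told apart. Against the unsubstituted parent the step is clear: a 2.4-fold lower number from compound 1 to compound 3 (0.39 log units; beyond the scatter), and the parallel step a 2.3-fold lower number from compound 1 to compound 2 (0.35 log units; beyond the scatter) is of the same size. Substitution on that aromatic carbon therefore moves the number down by a modest, reproducible amount, and the two substituents tried so far are indistinguishable in this assay.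

Compound 4 `CC1(C)OC(C)(C)c2c1nnc(-c1cccc(Cl)c1)[n+]2[O-]` is the next member. Its change from compound 3 is chloro in place of trifluoromethyl on an aromatic carbon. For the measured compounds named here, no measured step swaps trifluoromethyl for chloro directly; the bearing steps are the two substituent introductions from compound 1 and the flat step from compound 2 to compound 3. On this basis a third substituent at the same carbon is expected to keep the number near that of compound 3, with any step staying within the scatter: a 1.2-fold higher number from compound 3 to compound 4 (0.08 log units; within the scatter) is the expected step. For compound 4 the estimate in this assay is 80 mg/kg, with a range from 45 mg/kg to 150 mg/kg.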

Compound 4, dose for half-maximal effect: 500 mg/kg
For compound 4 the middle estimate is 6.3-fold (0.80 log units) below the measured one; the whole stated range lies below it.
By their numbers in this assay, from the lowest: compounds 3 and 2 (each within the scatter of the next); then compound 1; then compound 4.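

In this assay, substitution on this aromatic carbon no longer runs in one direction: chloro in place of hydrogen moves the number up (a 3.1-fold higher number from compound 1 to compound 4 (0.49 log units; beyond the scatter)), so the lowering seen with nitro and trifluoromethyl holds for compound 2 and compound 3 only, and compound 4 goes against it. The position therefore discriminates between substituents, which the flat step between compound 2 and compound 3 could not show: exchanging trifluoromethyl for chloro is not a neutral swap (a 7.5-fold higher number from compound 3 to compound 4 (0.87 log units; beyond the scatter)), and exchanging nitro for chloro gives a step beyond the scatter as well (a 6.9-fold higher number from compound 2 to compound 4 (0.84 log units; beyond the scatter)). Nothing available on these compounds explains why chloro parts from the other two substituents.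

Still open, on these data alone, is whether chloro stands alone at this carbon or whether fluoro, bromo or methyl would follow it rather than trifluoromethyl and nitro. Also open, as far as these compounds go, is how an amine, a carboxylic acid or a methoxy group would read at the same carbon, and whether chloro on another carbon of the aromatic ring would give the same upward step from compound 1.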